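A few compounds are considered here, and "the series" means these few. Any claim that something is new, unique, unknown or untested is made for them only; others in the source may bear on it.

Working notes on a glucosamide series measured in a physicochemical assay for lipophilicity, measured as octanol-water partition; on this read-out higher numbers stand for higher lipophilicity and lower numbers for lower lipophilicity.

Compound 1, `CCc1ccc(/C=C/C(=O)N[C@@H]2O[C@H](CO)[C@@H](O)[C@H](O)[C@H]2O)cc1`, gives 0.04 in this assay. Compound 2, `CC[C@H](CC(=O)N[C@@H]1O[C@H](CO)[C@@H](O)[C@H](O)[C@H]1O)c1ccc(C)c(C)c1`, gives 0.01, and compound 3, `Cc1ccccc1[C@H](Cc1ccco1)C(=O)N[C@@H]1O[C@H](CO)[C@@H](O)[C@H](O)[C@H]1O`, gives 0.004. The three numbers sit together: the gaps from compound 1 to compound 2 and to compound 3 both lie within the scatter of the method, so no ordering among them can be read from these values.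

Compound 4, `O=C(/C=C/c1ccc(-c2ccccc2)cc1)N[C@@H]1O[C@H](CO)[C@@H](O)[C@H](O)[C@H]1O`, is not yet measured. It differs from compound 1 in one place: phenyl in place of ethyl on an aromatic carbon. Within the data shown here, no measured pair shows this exchange, so the size of the step has to be estimated from the change itself. The step from compound 1 to compound 4 is expected to be a number 0.91 log units higher from compound 1 to compound 4 (beyond the scatter), upward and beyond the scatter. For compound 4 the value in this assay is estimated at 0.95, in the range 0.55 to 1.4.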

Compound 4, partition coefficient: 0.851
Compound 4: the middle estimate sits 0.10 log units above what was measured; the measured number falls inside the stated range.
By their numbers in this assay, from the lowest: compounds 3, 2 and 1 (each within the scatter of the next); then compound 4.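

At this aromatic carbon, para to a large group, phenyl in place of ethyl gives a step that can be read in this assay, a number 0.81 log units higher from compound 1 to compound 4 (beyond the scatter), and it lies beyond the scatter. Among these compounds, the earlier compounds held no pair differing in one place, so this is the first size attached to any single change. Nothing at hand bears on the origin of the step.

Going by these compounds, whether a longer alkyl chain or a pyridyl ring at this carbon would give a similar step stays open. So does whether the same exchange carries over to a core other than that of compound 1.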